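This account rests on a few compounds, and the source may have more. Where it says the series, first, only, none or still open, it means among the compounds named here.

Three 1,2,4-triazole-type compounds bearing a methyl on a ring nitrogen were examined in a functional assay on the whole organism for antagonist activity, with Mus musculus as the target, in the maximal electroshock model; on this read-out higher numbers stand for an effect only at larger amounts of compound and lower numbers for an effect already at smaller amounts. Compound 1 `Cn1c(-c2cccc(F)c2)nnc1S(C)(=O)=O` reached only a limit of the assay, > 200 mg/kg. Compound 2 `CSc1nnc(-c2cccc(F)c2)n1C` likewise gave only a limit, > 200 mg/kg. The step that the two limits leave unreadable from compound 2 to compound 1 is methylsulfonyl in place of methylsulfanyl on an aromatic carbon. Within the data shown here, compound 3 `CSc1nc(-c2ccc(Cl)cc2)nn1C` also stopped at a limit, > 200 mg/kg, so that the limit of > 200 mg/kg in this assay, at which 3 of the 3 values shown sit, holds for every value so far. The difference between the cores of compound 3 and compound 2 is not broken down here. Compound 4 `Cn1nc(-c2ccc(Cl)cc2)nc1S(C)(=O)=O` differs from compound 3 by methylsulfonyl in place of methylsulfanyl on an aromatic carbon, the same change as that from compound 2 to compound 1. Since compound 3 sits at > 200 mg/kg and the earlier step left compound 1 at the same limit, compound 4 is expected to give about 300 mg/kg, a step that the limit leaves unreadable from compound 3 to compound 4, most likely again reported only as a limit.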

Compound 4, dose for half-maximal effect: > 200 mg/kg
Compound 4 was reported as a limit; the forecaster's own chance of this, stated with the estimate: 85%; the middle value does not contradict the limit.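

Compound 4, like compound 3, gave only a limit, so no step between compound 3 and compound 4 can be read: the limit of > 200 mg/kg in this assay, at which 4 of the 4 values shown sit.

The compounds shown leave open how methylsulfonyl and methylsulfanyl compare in this assay.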